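The compounds below may be only part of what the source reports. "The series", "measured", "known", "first", "only" and "open" are said of these compounds alone.

Measured in a functional assay on HL-60 cells (Homo sapiens) for cytotoxicity, read by WST assay, with a stated time of 48 h; a higher number here means that more compound is needed for the effect, a lower number that less compound is needed:
- Compound 1 `Cc1ccccc1C[C@H]1COC(=O)[C@@H]1Cc1ccc(Cl)c(Cl)c1`: 22000 nM
- Compound 2 `Cc1ccc(C[C@H]2COC(=O)[C@@H]2Cc2ccc(Cl)c(Cl)c2)cc1`: 19000 nM
- Compound 3 `O=C1OC[C@H](Cc2ccc(F)cc2)[C@H]1Cc1ccc(Cl)c(Cl)c1`: 14000 nM

The three numbers sit level, so compound 3 holds no clear place among them. All three measured steps change the aromatic group at one place, and each stays within the usual scatter: a 1.2-fold lower number from compound 1 to compound 2 (0.06 log units; within the scatter), a 1.6-fold lower number from compound 1 to compound 3 (0.20 log units; within the scatter) and a 1.4-fold lower number from compound 2 to compound 3 (0.13 log units; within the scatter).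

Compound 4 `O=C1OC[C@H](Cc2ccc(Cl)c(Cl)c2)[C@H]1Cc1ccc(Cl)c(Cl)c1` has not yet been measured. It carries 3,4-dichlorophenyl in place of 4-fluorophenyl on a saturated chain carbon bound to a saturated ring carbon. The same place has already been varied, so the three measured steps are the best guide. However, none of the measured compounds has 3,4-dichlorophenyl there, which leaves the estimate uncertain.

As far as these compounds go, no step beyond the scatter is therefore expected in this assay, and the direction remains open. The expected change is a 1.2-fold lower number from compound 3 to compound 4 (0.07 log units; within the scatter). For compound 4 the estimated value is 12000 nM, within an expected range from 5000 nM to 25000 nM.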

Compound 4, half-maximal effective concentration: 20000 nM
For compound 4 the middle estimate is 1.7-fold (0.22 log units) below the measured one; the measured number falls inside the stated range.
By their numbers in this assay, from the lowest: compounds 3, 2, 4 and 1 (each within the scatter of the next).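

In this assay, placing 3,4-dichlorophenyl on this saturated chain carbon bound to a saturated ring carbon gives no step beyond the scatter against any of the three earlier groups: 4-fluorophenyl (a 1.4-fold higher number from compound 3 to compound 4 (0.15 log units; within the scatter)), 4-methylphenyl (a 1.1-fold higher number from compound 2 to compound 4 (0.02 log units; within the scatter)) and 2-methylphenyl (a 1.1-fold lower number from compound 1 to compound 4 (0.04 log units; within the scatter)). Going by these compounds alone, the earlier compounds carried only a single fluoro or methyl group on this aromatic ring, so compound 4 extends the flat picture to a ring with two chloro groups, and all four compounds now read as level. Nothing available explains why this place responds so little to these changes.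

As far as these compounds go, all four groups here are substituted phenyl rings, so it remains open whether an amine, a carboxylic acid or a longer chain at this place would move the number beyond the scatter. The other 3,4-dichlorophenyl group stays the same throughout, which leaves the effect of changing it unknown.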